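The source may hold more compounds than are shown below. What is called first, only, known or untested is meant among the compounds shown, and "the series" means these compounds.

Compound 1 `N#Cc1ccc(Nc2cc(NS(=O)(=O)c3ccc(F)cc3)ccn2)cc1` and compound 2 `Cc1cc(C)cc(S(=O)(=O)Nc2ccnc(Nc3ccc(C#N)cc3)c2)c1` share one core, while compound 3 `N#Cc1ccc(Nc2nccc(NS(=O)(=O)c3ccc(F)cc3)n2)cc1` and compound 4 `Cc1cc(C)cc(S(=O)(=O)Nc2ccnc(Nc3ccc(C#N)cc3)n2)c1` share another. In an ADME assay on MT4 cells (Homo sapiens) for cytotoxicity, read by MTT assay, with a stated time of 5 days (a lower number here means that less compound is tolerated, a higher number that more compound is tolerated), compound 1 gives 6120 nM, and compound 2 gives 5060 nM. The change between them is 3,5-dimethylphenyl in place of 4-fluorophenyl on a sulfonyl sulfur, and it made a step of a 1.2-fold lower number from compound 1 to compound 2 (0.08 log units; within the scatter), so the two numbers cannot be told apart. Compound 3 gives 36600 nM in this assay, the highest of the three numbers measured, and the difference between its core and the core of compound 1 is not broken down here. Compound 4 is reached from compound 3 by 3,5-dimethylphenyl in place of 4-fluorophenyl on a sulfonyl sulfur, the same kind of change already seen from compound 1 to compound 2, at a place described in the same words. The step from compound 3 to compound 4 in this assay is therefore expected to be about as small, a 1.1-fold lower number from compound 3 to compound 4 (0.06 log units; within the scatter), because the earlier step of a 1.2-fold lower number from compound 1 to compound 2 (0.08 log units; within the scatter) stayed within the scatter. On that basis compound 4 is estimated to give 32000 nM in this assay, most likely between 12000 nM and 85000 nM.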

Compound 4, half-maximal cytotoxic concentration: 173000 nM
Compound 4: middle estimate off by 5.4-fold (0.73 log units), on the low side, and the stated range ends below it.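

In this assay, putting 3,5-dimethylphenyl in place of 4-fluorophenyl on a sulfonyl sulfur gives a step of a 4.7-fold higher number from compound 3 to compound 4 (0.67 log units; beyond the scatter), so more compound is tolerated after the change on this core. The same swap therefore does not carry over with the same size from one core to the other in this series: the same change on two cores in this assay, a 1.2-fold lower number (0.08 log units; within the scatter) from compound 1 to compound 2 and a 4.7-fold higher number (0.67 log units; beyond the scatter) from compound 3 to compound 4, 5.7-fold (0.76 log units) apart, beyond the scatter of two such steps. This rests on a single pair on each core, so it shows that a step seen on one core cannot simply be copied to the other, but it does not show which part of the core sets the size of the step or what the swap would do on a third core.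

Among the compounds shown, only these two groups sit on the sulfonyl sulfur. From the compounds shown here alone, it remains open whether the two cores would also part ways with a different group there, such as a plain phenyl, a single methyl-bearing phenyl or a phenyl carrying an amine.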